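The compounds below may be only part of what the source reports. "The series", "measured", "known", "first", "only" and "open" are said of these compounds alone.

Measured compounds:

Compound 1, `CCc1sc(CCc2cc(OC)cc(NCc3cc(Cl)cc(NC(=O)OC(C)C)c3)n2)nc1C`, in an assay on cells for binding affinity to Neuropeptide Y receptor type 1 (Homo sapiens) (on this read-out lower numbers stand for stronger inhibition and higher numbers for weaker inhibition), compound 1 gives 234 nM.
Compound 2, `CCCCCCCOc1cc(CCc2nc(C)c(CC)s2)nc(NCc2cc(Cl)cc(NC(=O)OC(C)C)c2)c1`, in this assay compound 2 gives 72 nM.
Compound 3, `CCc1sc(CCc2cc(OC(C)C)cc(NCc3cc(Cl)cc(NC(=O)OC(C)C)c3)n2)nc1C`, in this assay compound 3 gives 12 nM.

Compound 3 has the lowest number of the three, and both of its steps to the others lie beyond the scatter: a 6.0-fold lower number from compound 2 to compound 3 (0.78 log units; beyond the scatter) and a 20-fold lower number from compound 1 to compound 3 (1.29 log units; beyond the scatter). All three share the same core and differ only in the group on an oxygen on an aromatic ring.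

Compound 4, `CCc1sc(CCc2cc(OC(CC)CC)cc(NCc3cc(Cl)cc(NC(=O)OC(C)C)c3)n2)nc1C`, continues that series. It differs from compound 3 in one place: pentan-3-yl in place of isopropyl on an oxygen on an aromatic ring.

For the measured compounds named here, three measured steps bear on this change, all at the same oxygen. Going from methyl to isopropyl, a 20-fold lower number from compound 1 to compound 3 (1.29 log units; beyond the scatter). Going from methyl to heptyl, a 3.3-fold lower number from compound 1 to compound 2 (0.51 log units; beyond the scatter). Going from heptyl to isopropyl, a 6.0-fold lower number from compound 2 to compound 3 (0.78 log units; beyond the scatter). Taken together, the branched isopropyl gave the lowest number, while the long chain gave a smaller gain than the branch did. Pentan-3-yl keeps the branching and adds length, so no large move in this assay is expected, and the direction is open. The step from compound 3 to compound 4 is therefore estimated as a 1.3-fold higher number from compound 3 to compound 4 (0.10 log units; within the scatter). On that basis compound 4 is expected to give about 15 nM, within a range from 4 nM to 60 nM.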

Compound 4, half-maximal inhibitory concentration: 5.5 nM
For compound 4 the middle estimate is 2.7-fold (0.44 log units) above the measured one; low and high end bracket the measured number.
By their numbers in this assay, from the lowest: compound 4; then compound 3; then compound 2; then compound 1.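

At this oxygen on an aromatic ring, the benefit of branching did not stop at isopropyl: in this assay, swapping it for pentan-3-yl gives a further modest gain (a 2.2-fold lower number from compound 3 to compound 4 (0.34 log units; beyond the scatter)), and lower numbers here mean stronger inhibition. Added carbon alone does not set the number, since pentan-3-yl also stands well ahead of the long heptyl chain (a 13-fold lower number from compound 2 to compound 4 (1.12 log units; beyond the scatter)). Against the small methyl group the total gain at this oxygen now reaches its largest size (a 43-fold lower number from compound 1 to compound 4 (1.63 log units; beyond the scatter)), and across the four groups heptyl is the one that goes against any simple rule that more carbon gives a lower number, as it ranks behind both branched groups.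

Nothing measured here explains why the branched groups give the lower numbers. Going by these compounds, it also remains open whether the trend continues with a larger branched group such as heptan-4-yl, or whether a ring on the same oxygen, such as cyclopentyl, or a chain carrying an amine would keep the number this low.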